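The source may hold more compounds than are shown below. What is called first, only, known or untested is meant among the compounds shown, and "the series" means these compounds.

Measured so far in an assay on isolated protein (strain albino) for antagonist activity at Voltage-dependent L-type calcium channel subunit alpha-1C (Cavia porcellus); a higher number here means a weaker inhibitor, a lower number a stronger inhibitor:
compound 1 `COC(=O)C1=C(C)NC(C)=C(C(=O)OCc2ccccc2)C1c1cnc(SC)n1Nc1ccccc1` gives 2.21 nM;
compound 2 `COC(=O)C1=C(C)NC(C)=C(C(=O)OCCCc2ccccc2)C1c1cnc(SC)n1Nc1ccccc1` gives 3.05 nM;
compound 3 `CCOC(=O)C1=C(C)NC(C)=C(C(=O)OCc2ccccc2)C1c1cnc(SC)n1Nc1ccccc1` gives 1.86 nM.

All three share one core and differ only at the two ester groups. Compound 2 differs from compound 1 by phenethyl in place of phenyl on a saturated chain carbon bound to an oxygen next to a carbonyl group, and that change gave a 1.4-fold higher number from compound 1 to compound 2 (0.14 log units; within the scatter). Compound 3 differs from compound 1 by methyl in place of hydrogen on a saturated chain carbon bound to an oxygen next to a carbonyl group, giving a 1.2-fold lower number from compound 1 to compound 3 (0.07 log units; within the scatter). Both steps are within the scatter, so the three values are not distinguished from one another.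

Compound 4 `CCOC(=O)C1=C(C)NC(C)=C(C(=O)OCCCc2ccccc2)C1c1cnc(SC)n1Nc1ccccc1` is not yet measured. It differs from compound 3 by phenethyl in place of phenyl on a saturated chain carbon bound to an oxygen next to a carbonyl group, the same change as from compound 1 to compound 2, made here on the core of compound 3 rather than that of compound 1. Since that earlier step was within the scatter, the step from compound 3 to compound 4 in this assay is expected to be of the same small size, a 1.4-fold higher number from compound 3 to compound 4 (0.15 log units; within the scatter), resting on a 1.4-fold higher number from compound 1 to compound 2 (0.14 log units; within the scatter) and on the value of compound 3, 1.86 nM. Compound 4 is therefore estimated at 2.6 nM, with a likely range from 1.3 nM to 5.2 nM.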

Compound 4, half-maximal inhibitory concentration: 2.54 nM
Compound 4: the middle estimate sits 1.0-fold (0.01 log units) above what was measured; the range from low to high includes it.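

In this assay, the change from benzyl to 3-phenylpropyl on the ester gives a 1.4-fold higher number from compound 3 to compound 4 (0.14 log units; within the scatter), and it carries from the core of compound 1 to the core of compound 3 with no visible difference: the same change on two cores in this assay, a 1.4-fold higher number (0.14 log units; within the scatter) from compound 1 to compound 2 and a 1.4-fold higher number (0.14 log units; within the scatter) from compound 3 to compound 4, 1.0-fold (0.00 log units) apart, within the scatter of two such steps. Methyl in place of hydrogen on a saturated chain carbon bound to an oxygen next to a carbonyl group gives a 1.2-fold lower number from compound 2 to compound 4 (0.08 log units; within the scatter), and this change also reads alike on both cores: the same change on two cores in this assay, a 1.2-fold lower number (0.07 log units; within the scatter) from compound 1 to compound 3 and a 1.2-fold lower number (0.08 log units; within the scatter) from compound 2 to compound 4, 1.0-fold (0.00 log units) apart, within the scatter of two such steps. Among the compounds shown here, all of these steps lie within the scatter, so the agreement shows only that neither change has a detectable effect on either core; it does not show that a step of real size would carry from one core to another.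

The compounds shown leave open whether a larger step appears with a carboxylic acid, an amine or a longer chain in place of the 3-phenylpropyl group. They also leave open whether such a step would then carry between the two cores.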